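This account rests on a few compounds, and the source may have more. Where it says the series, first, only, none or still open, it means among the compounds named here.

Measured so far:
compound 1, `CCNc1nc2ccsc2c(=O)n1CC`: 240 ug/mL
compound 2, `CCn1c(N[C@H]2CC[C@H](C(=O)O)CC2)nc2ccsc2c1=O`: 450 ug/mL

In a physicochemical assay for solubility, in phosphate buffer, at pH 6.8 (on this read-out higher numbers stand for higher solubility and lower numbers for lower solubility), compound 2 gives 450 ug/mL, the higher of the two numbers, though its gap to compound 1 falls within the scatter, so no order can be read from the pair. Compound 3, `CCn1c(N[C@H]2CC[C@H](O)CC2)nc2ccsc2c1=O`, is not yet measured; it differs from compound 2 by hydroxy in place of carboxy on a saturated ring carbon. Among the compounds with values here, no step between measured compounds shows what this change does. Compound 3 is expected to give a lower number, by a step of a 1.8-fold lower number from compound 2 to compound 3 (0.26 log units; within the scatter), modestly beyond the scatter. The estimated solubility of compound 3 is 250 ug/mL, with a range of 100 ug/mL to 600 ug/mL.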

Compound 3, solubility: 74 ug/mL
Compound 3: middle estimate off by 3.4-fold (0.53 log units), on the high side; the measured number lies below the stated range.
By their numbers in this assay, from the lowest: compound 3; then compounds 1 and 2 (each within the scatter of the next).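

Putting hydroxy in place of carboxy on the saturated ring carbon brings a 6.1-fold lower number from compound 2 to compound 3 (0.78 log units; beyond the scatter) in this assay. Within the data shown here, this is the first step between measured compounds that differ in one place, and it shows that the number at this position depends on which of these two groups the ring carbon carries. No evidence here explains the size of this step. The compounds shown leave open whether an amine, an amide or a longer chain ending in a carboxylic acid at this ring carbon would give a number closer to that of compound 2 or compound 3. They also leave open whether the same change would give a similar step on another core.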